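Swapping the ring on the carbonyl carbon

The source may report more compounds than this note shows. Statements on the series, on what has been measured and on what is new or still open speak of the compounds shown alone.

Compound 1 `CCOc1nc(Nc2ccc(C(=O)NCC(C)(C)O)cc2OC)nc2[nH]ccc12`: 12.6 nM
Compound 2 `CCOc1nc(Nc2ccc(C(=O)N3C[C@@H](C)O[C@@H](C)C3)cc2OC)nc2[nH]ccc12`: 63.1 nM

Among the compounds with values here, compound 2 has the higher of the two numbers measured so far in an assay on isolated protein for inhibition of Leucine-rich repeat serine/threonine-protein kinase 2 (Homo sapiens), read by TR-FRET, with stated times of 30 min and 2 h, in the presence of a further agent that is not named here; a higher number here means a weaker inhibitor, a lower number a stronger inhibitor; its nearest neighbour is compound 1, which differs only at the carbonyl carbon. Compound 3 `CCOc1nc(Nc2ccc(C(=O)N3CC4(COC4)C3)cc2OC)nc2[nH]ccc12` carries a group of 7 heavy atoms (5 carbon, 1 nitrogen, 1 oxygen; 2 four-membered non-aromatic rings with 1 hetero atom each) in place of a group of 8 heavy atoms (6 carbon, 1 nitrogen, 1 oxygen; one six-membered non-aromatic ring with 2 hetero atoms), on a carbonyl carbon. Within the data shown here, the only measured step at that position, a 5.0-fold higher number from compound 1 to compound 2 (0.70 log units; beyond the scatter), concerns a different pair of groups, so it gives just a rough guide: changing the group on the carbonyl carbon can shift the number noticeably. For compound 3 a step of a 1.3-fold lower number from compound 2 to compound 3 (0.10 log units; within the scatter) is expected, within the scatter, giving an estimate of 50 nM with a range from 15 nM to 160 nM.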

Compound 3, half-maximal inhibitory concentration in the Leucine-rich repeat serine/threonine-protein kinase 2 assay: 63.1 nM
Beside the measured number, compound 3's estimate is 1.3-fold (0.10 log units) below it; the measured number falls inside the stated range.
By their numbers in the Leucine-rich repeat serine/threonine-protein kinase 2 assay, from the lowest: compound 1; then compounds 2 and 3 (each within the scatter of the next).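

At the carbonyl carbon, the Leucine-rich repeat serine/threonine-protein kinase 2 assay does not separate the two ring-bearing groups, with no change at the digits printed from compound 2 to compound 3 (within the scatter), and the group of compound 3 remains weaker than the open chain of compound 1, with a 5.0-fold higher number from compound 1 to compound 3 (0.70 log units; beyond the scatter). In a physicochemical assay for lipophilicity, at pH 7.4 (a lower number here means a more polar compound, a higher number a more lipophilic compound), compound 2 gives 5.7 and compound 3 gives 4.3. The same swap does register in the physicochemical assay, so at this position a compound can become much less lipophilic without a shift in inhibition beyond the scatter: the measured distribution coefficient of compound 2, 5.7, and of compound 3, 4.3, a number 1.40 log units lower (beyond the scatter)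

Still open, on these data alone, is whether a piperazine ring or a longer chain ending in a hydroxyl group on the carbonyl carbon could match compound 1 in the Leucine-rich repeat serine/threonine-protein kinase 2 assay while staying as low as compound 3 in the physicochemical assay.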